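Side-chain exchange from compound 3 to compound 4

The source may report more compounds than this note shows. Statements on the series, on what has been measured and on what is new or still open speak of the compounds shown alone.

The compounds share one core and differ in a side chain, and all are read in a functional assay on HepG2 cells (Homo sapiens) for cytotoxicity, read by MTT assay, with a stated time of 48 h; a higher number here means a weaker inhibitor, a lower number a stronger inhibitor. Compound 1 (`C=CC(C)(O)CC[C@@H]1C(=C)CC[C@H](Br)[C@@]1(C)CCC(Br)C(C)(C)O`) gives > 100000 nM; 66300 nM (2 entries) over its entries. One of those entries is a limit of the assay. Compound 2 (`C=CC(C)(O)CC[C@@H]1C(=C)CC[C@H](Br)[C@@]1(C)CCC(OC)C(C)(C)O`) gives > 100000 nM as a limit of the assay. Among the measured compounds shown here, compound 3 (`C=CC(C)(O)CC[C@@H]1C(=C)CC[C@H](Br)[C@@]1(C)CCC1OC1(C)C`) gives 53800 nM as the only single number among the three, so its standing against the others is loosely fixed.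

Compound 4 (`C=CC(C)(O)CC[C@@H]1C(=C)CC[C@H](Br)[C@@]1(C)CCC(O)C(=C)C`) carries 1-hydroxy-2-methylprop-2-en-1-yl in place of 3,3-dimethyloxiran-2-yl on a saturated chain carbon, two bonds along the chain from a saturated ring carbon. The nearest measured step runs the other way between open chain and oxirane: an at least 1.8-fold lower number from compound 2 to compound 3 (0.26 log units; that floor lies within the scatter) is its size, and that floor stays within the scatter. The open-chain readings add little, given the several entries of compound 1 in this assay, > 100000 nM; 66300 nM (2 entries) and the limit of > 100000 nM in this assay, at which 1 of the 3 values shown sits, as the basis. No step beyond the scatter is therefore expected in this assay, with a slight lean towards a higher number and a real chance of a limit reading. The expected change is a 1.3-fold higher number from compound 3 to compound 4 (0.11 log units; within the scatter) and remains within the scatter. For compound 4 the estimated value is 70000 nM with an expected range of 38000 nM to 130000 nM in this assay.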

Compound 4, half-maximal inhibitory concentration: > 100000 nM
Compound 4 gave a limit, no number (the forecaster's own chance of this, stated with the estimate: 35%); at least 1.4-fold (0.15 log units) between middle value and limit.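

Putting 1-hydroxy-2-methylprop-2-en-1-yl in place of 3,3-dimethyloxiran-2-yl on a saturated chain carbon, two bonds along the chain from a saturated ring carbon, gives an at least 1.8-fold higher number from compound 3 to compound 4 (0.26 log units; that floor lies within the scatter) in this assay. The reading for compound 4, > 100000 nM, is a limit of the assay, so only a floor is available for this step, and the step from compound 2 to compound 4 cannot be read. This change keeps the same atoms joined differently, opening the ring and adding a hydrogen-bond donor and a double bond, and it still yields another limit in the series: the limit of > 100000 nM in this assay, at which 2 of the 4 values shown sit.

On these data alone, the true size of the step from compound 3 to compound 4 remains open, and with it whether the three-membered ring, the hydroxy group or the double bond matters at this position, since these features change together in this single exchange. As far as these compounds go, how an amine or a carboxylic acid would read at the same place on the shared core also remains open.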